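The compounds below may be only part of what the source reports. "The series", "measured", "known", "first", "only" and "open" are said of these compounds alone.

Of the compounds shown here, three have so far been tested in a functional assay on the whole organism for inhibition, with Artemia salina as the target; on this read-out higher numbers stand for weaker inhibition of growth and lower numbers for stronger inhibition of growth. Compound 1 `CO[C@H]1C[C@H](O[Si](C)(C)C(C)(C)C)O[C@@H](C)/C1=C\COC(=O)c1ccncc1` gives 0.01 ug/mL. Among the compounds with values here, compound 3 `CO[C@H]1C[C@H](O[Si](C)(C)C(C)(C)C)O[C@@H](C)/C1=C\COC(=O)c1cccnc1` gives 0.002 ug/mL, and the single measured step between two compounds, a number 2.3 two-fold dilutions lower from compound 1 to compound 3 (beyond the scatter), is the only guide so far to how a structural change moves the read-out. Compound 2 `C=CCOC(=O)/C=C1/[C@H](C)O[C@@H](O[Si](C)(C)C(C)(C)C)C[C@@H]1OC` gives 0.002 ug/mL, level with compound 3 at the digits shown; the two stand together at the lowest numbers, while compound 1 sits higher, beyond the scatter.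

Compound 4 `CO[C@H]1C[C@H](O[Si](C)(C)C(C)(C)C)O[C@@H](C)/C1=C/C(=O)O` has not yet been measured. It differs from compound 2 in one place: hydrogen in place of allyl on an oxygen next to a carbonyl group. Within the data shown here, no measured step covers this kind of change. Among the measured compounds shown here, the one step available, a number 2.3 two-fold dilutions lower from compound 1 to compound 3 (beyond the scatter), exchanges one aromatic ring for another inside the ester and leaves the ester itself untouched, whereas here the ester of compound 2 becomes a free carboxylic acid in compound 4. The expectation therefore rests on thin ground and carries a wide range. Compound 4 is estimated to give about 0.02 ug/mL, most likely between 0.002 ug/mL and 0.2 ug/mL. The expected step a number 3.3 two-fold dilutions higher from compound 2 to compound 4 (beyond the scatter) is an estimate toward weaker inhibition, though a result within the scatter would not surprise.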

Compound 4, minimum inhibitory concentration: 0.002 ug/mL
The estimate for compound 4 lay 3.3 two-fold dilutions above the measured number; the range from low to high includes it.
By their numbers in this assay, from the lowest: compounds 2, 3 and 4 (each within the scatter of the next); then compound 1.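

In this assay, hydrogen in place of allyl on an oxygen next to a carbonyl group gives no change at the digits printed from compound 2 to compound 4 (within the scatter). Within the data shown here, the one earlier step exchanged one aromatic ring for another inside the ester, whereas this step removes the ester's allyl group, leaving a free carboxylic acid, and shows that allyloxycarbonyl and carboxy stand level in this pair. Nothing in the data at hand explains why the read-out holds when the allyl group leaves.

As far as these compounds go, it remains open whether this holds for other groups on the same oxygen, such as a methyl group or a longer chain. An amide in place of the carboxylic acid is also untested among the compounds shown, so how far the read-out tolerates change at this place is unknown.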